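This account rests on a few compounds, and the source may have more. Where it says the series, first, only, none or still open, it means among the compounds named here.

Measured compounds:
- compound 1 `CCCc1nn(Cc2ccccc2)c(C(=O)O)c1Cc1ccc(-c2ccccc2-c2nn[nH]n2)cc1`: 100%
- compound 2 `CCCc1nn(-c2c(Cl)cccc2Cl)c(C(=O)O)c1Cc1ccc(-c2ccccc2-c2nn[nH]n2)cc1`: 87%

In a functional assay on the whole organism for inhibition, with Rattus norvegicus as the target, at a dose of 1 mg/kg by the oral route (a lower number here means less inhibition, a higher number more inhibition at the dose given (going by the name of the read-out)), compound 1 gives 100% and compound 2 gives 87%. Going by the values given here, compound 2 thus stands lowest of the two numbers, with compound 1 its only neighbour; the single measured step is a number 13 percentage points lower from compound 1 to compound 2 (beyond the scatter), a modest fall that lies beyond the scatter.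

Compound 3 `CCCc1nn(-c2ccccc2C(F)(F)F)c(C(=O)O)c1Cc1ccc(-c2ccccc2-c2nn[nH]n2)cc1` is the next member. Its change from compound 2 is 2-(trifluoromethyl)phenyl in place of 2,6-dichlorophenyl on an aromatic nitrogen. Among the compounds with values here, only one step bears on it: the step from compound 1 to compound 2, which exchanged a benzyl for a 2,6-dichlorophenyl on the same aromatic nitrogen and cost a number 13 percentage points lower from compound 1 to compound 2 (beyond the scatter). Within the data shown here, no measured step exchanges one substituted phenyl for another at this position, so there is no direct precedent for the size of the present change. Since both compounds carry a substituted phenyl on that nitrogen and the measured value of compound 2 is already high, the expectation is for a step from compound 2 to compound 3 of about a number 5 percentage points lower from compound 2 to compound 3 (within the scatter), which is within the scatter. Compound 3 is therefore estimated at 82%, with a range from 60% to 100%.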

Compound 3, a percentage reported as inhibition, in the whole organism at one dose (the size of the read-out at that dose, not a potency): 71%
Compound 3: middle estimate off by 11 percentage points, on the high side; low and high end bracket the measured number.
By their numbers in this assay, from the lowest: compound 3; then compound 2; then compound 1.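

In this assay, exchanging one substituted phenyl for another on the aromatic nitrogen still moves the read-out, giving a number 16 percentage points lower from compound 2 to compound 3 (beyond the scatter); at this position, the two aryl groups are therefore not interchangeable. Set against the benzyl group, the 2-(trifluoromethyl)phenyl group gives a number 29 percentage points lower from compound 1 to compound 3 (beyond the scatter), which places compound 3 lowest of the three in this assay, with its steps to both others printed as beyond the scatter. Nothing measured on these compounds speaks to the reason for this fall.

The step from compound 2 to compound 3 swaps the substituents on the phenyl ring all at once, so the effect of adding trifluoromethyl cannot be separated from that of removing the two chlorines. From the compounds shown here alone, an unsubstituted phenyl, a 2-chlorophenyl or a 2-methoxyphenyl on this nitrogen would help to separate them, while a phenethyl group would show whether a longer chain than the benzyl carbon keeps the read-out of compound 1, and all of this remains open at the single dose of this read-out.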